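Adding an amino group to the acetyl of compound 1

The source may report more compounds than this note shows. Statements on the series, on what has been measured and on what is new or still open speak of the compounds shown alone.

For the measured compounds named here, in a functional assay on HCT-15 cells (Homo sapiens) (on this read-out higher numbers stand for an effect only at larger amounts of compound and lower numbers for an effect already at smaller amounts), compound 1 `COc1cc(C2OC(c3ccc(N(C)C)cc3)=NN2C(C)=O)cc(OC)c1OC` gives 0.033 uM, the lowest of the three numbers so far. Compound 4 `COc1cc(C2OC(c3ccc(N(C)C)cc3)=NN2C(=O)CN)cc(OC)c1OC` keeps the same core but has amino in place of hydrogen on a saturated chain carbon bound to a carbonyl carbon, so acetyl becomes (aminomethyl)carbonyl (amino in place of hydrogen on a saturated chain carbon bound to a carbonyl carbon). Going by the values given here, no measured compound changes this place. The nearest guides are compound 2 `COc1cc(C2OC(c3ccccc3N(C)C)=NN2C(C)=O)cc(OC)c1OC`, which gives 65 uM, and compound 3 `COc1cc(C2OC(c3ccc(N(C)C)cc3)=NN2C(C)=O)cc(OC)c1OC(C)=O`, which gives 78 uM. Their changes lie elsewhere on the molecule, and both are large and upward: a 2000-fold higher number from compound 1 to compound 2 (3.29 log units; beyond the scatter) and a 2400-fold higher number from compound 1 to compound 3 (3.37 log units; beyond the scatter). With only these indirect steps to go on, a smaller upward move is expected, estimated as a 15-fold higher number from compound 1 to compound 4 (1.18 log units; beyond the scatter). For compound 4 the expected value is 0.5 uM, with an estimated range from 0.04 uM to 10 uM.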

Compound 4, concentration for half-maximal effect: 0.65 uM
Compound 4: middle estimate off by 1.3-fold (0.11 log units), on the low side; the measured number falls inside the stated range.
By their numbers in this assay, from the lowest: compound 1; then compound 4; then compounds 2 and 3 (each within the scatter of the next).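

In this assay, for the compounds shown here, the acetyl group itself is changed for the first time, and amino in place of hydrogen on a saturated chain carbon bound to a carbonyl carbon gives a 20-fold higher number from compound 1 to compound 4 (1.29 log units; beyond the scatter) on this read-out. This place therefore responds to a single added amino group, although the step is smaller than those from compound 1 to compound 2 or compound 3. Nothing available explains the rise. Still open, from the compounds shown here alone, is how a methylamino group, a hydroxyl group, a carboxylic acid or a longer chain would behave at this carbon.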